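The source may hold more compounds than are shown below. What is called first, only, known or untested is meant among the compounds shown, and "the series" means these compounds.

Compound 1, `CCC[C@@H](OC(C)=O)C1=C(Br)/C(=C/Br)OC1=O`: 1.6 ug/mL
Compound 2, `CCCCC1=C(Br)C(OC)(C(Br)Br)OC1=O`: 6.7 ug/mL
Compound 3, `CCC[C@@H](O)C1=C(Br)/C(=C\Br)OC1=O`: 0.3 ug/mL

In a functional assay on ZR-75-1 cells (Homo sapiens) for cytotoxicity (on this read-out higher numbers stand for an effect only at larger amounts of compound and lower numbers for an effect already at smaller amounts), compound 3 stands at the lowest of the three numbers, with 0.3 ug/mL. Compound 1 lies nearest to it, yet its value of 1.6 ug/mL is still beyond the scatter of the read-out, and compound 2 lies furthest away with 6.7 ug/mL. Since compound 1 and compound 2 each differ from compound 3 in more than one place, nothing is said here about what single change carries these gaps; only the three values themselves stand side by side.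

Compound 4, `CCC[C@@H](O)C1=C(Br)/C(=C/Br)OC1=O`, has not yet been measured in this assay. It relates to compound 3 as follows: the two compounds have the same atoms and bonds and differ only in configuration as drawn: 1 of 2 stereo elements differ; a double bond is drawn E in compound 3 and Z in compound 4. Among the compounds with values here, no step between two measured compounds shows what such a change in geometry does on this read-out. The account therefore expects only a modest shift, if any, and leans toward a slightly higher number for compound 4 than for compound 3, a step that may well stay within the scatter. On that basis compound 4 is estimated at 0.6 ug/mL, within a range from 0.2 ug/mL to 2 ug/mL, which would mean an expected step of a 2.0-fold higher number from compound 3 to compound 4 (0.30 log units; within the scatter).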

Compound 4, concentration for half-maximal effect: < 0.1 ug/mL
Compound 4 was reported as a limit; the forecaster's own chance of this, stated with the estimate: 5%; middle value at least 6.0-fold (0.77 log units) away from the limit.
By their numbers in this assay, from the lowest: compound 3; then compound 1; then compound 2. At a limit, below all of these: compound 4.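

In this assay, within the data shown here, a change in the drawn geometry of one double bond, with atoms and bonds untouched, gives an at least 3.0-fold lower number from compound 3 to compound 4 (0.47 log units; beyond the scatter), so this double bond's configuration alone moves the read-out beyond the scatter, something no earlier pair of compounds could show. With the drawn geometry held the same, hydrogen in place of acetyl on an oxygen on a saturated carbon gives an at least 16-fold lower number from compound 1 to compound 4 (1.20 log units; beyond the scatter), which ties the free hydroxyl to a large step on this read-out, whereas compound 1 and compound 3 had differed in two places at once. Compound 4 gives < 0.1 ug/mL, which is a limit, so both steps give only a smallest size.

Going by these compounds, how far the true value of compound 4 lies past that limit stays open, and so does whether acetyl in place of hydrogen would give a step of similar size with the double bond geometry of compound 3. Equally open, on these data alone, is what an amine in place of the hydroxyl, or a longer chain on the shared core, would do with either geometry on this read-out.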